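The compounds below may be only part of what the source reports. "The series", "measured", "known", "first", "only" and "open" are said of these compounds alone.

Working notes on the arylsulfonylurea series in a functional assay on the whole organism (6C3HED cells, Mus musculus) for inhibition, at a dose of 150 mg/kg by the oral route; a higher number here means more inhibition at the dose given (going by the name of the read-out), a lower number less inhibition. Compound 1 `COc1ccc(S(=O)(=O)NC(=O)Nc2ccc(Cl)cc2)s1` gives 93% in this assay, and compound 2 `CSc1ccc(S(=O)(=O)NC(=O)Nc2ccc(Cl)cc2)s1` gives 29%. Among the measured compounds shown here, the one step in the set, a number 64 percentage points lower from compound 1 to compound 2 (beyond the scatter), is the only measured change, and compound 2 therefore stands lowest of the two numbers, with compound 1 the nearer and only neighbour.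

Compound 3 `CCc1ccc(S(=O)(=O)NC(=O)Nc2ccc(Cl)cc2)o1` is not yet measured. It differs from compound 2 by 5-ethylfuran-2-yl in place of 5-(methylsulfanyl)thiophen-2-yl on a sulfonyl sulfur. For the measured compounds named here, no measured step exchanges both the ring hetero atom and the substituent at once; the step from compound 1 to compound 2 bears on it only in that a single change at that ring moved the read-out by a large amount. For compound 3 the step is estimated, with wide uncertainty, as a number 26 percentage points higher from compound 2 to compound 3 (beyond the scatter). Compound 3 is thus estimated at 55%, with a range from 15% to 90%.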

Compound 3, a percentage reported as inhibition, in the whole organism at one dose (the size of the read-out at that dose, not a potency): 57%
The estimate for compound 3 lay 2 percentage points below the measured number; the measured number falls inside the stated range.
By their numbers in this assay, from the lowest: compound 2; then compound 3; then compound 1.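

At the sulfonyl sulfur in this assay, 5-ethylfuran-2-yl in place of 5-(methylsulfanyl)thiophen-2-yl gives a number 28 percentage points higher from compound 2 to compound 3 (beyond the scatter), while the same group in place of 5-methoxythiophen-2-yl gives a number 36 percentage points lower from compound 1 to compound 3 (beyond the scatter). A substantial read-out at this position is therefore not confined to 5-methoxythiophen-2-yl, although that group retains the highest number of the three, and a change of ring and substituent together can recover part of the loss seen with 5-(methylsulfanyl)thiophen-2-yl. Nothing available accounts for these differences.

Both new steps alter the ring hetero atom and the substituent together, so the share of each remains unresolved. Going by these compounds, the 5-ethylthiophen-2-yl and 5-methoxyfuran-2-yl pair would separate them, and it remains open how an amine, a carboxylic acid or a longer chain in place of ethyl would read out.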